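The source may hold more compounds than are shown below. What is called first, only, known or untested is meant among the compounds shown, and "the series" means these compounds.

Measured compounds:
Compound 1 `N=C(N)N/N=C/c1cn(-c2ccc([N+](=O)[O-])cc2[N+](=O)[O-])nc1-c1ccccc1Br`: 78.1%
Compound 2 `N=C(N)N/N=C/c1cn(-c2ccccc2)nc1-c1ccc(F)cc1`: 61.4%

In a functional assay on the whole organism (Ear) for inhibition, with Mus musculus as the target, with a stated time of 30 min, at a dose of 50 mg/kg by the intraperitoneal route (a higher number here means more inhibition at the dose given (going by the name of the read-out), a lower number less inhibition), compound 1 gives 78.1% and compound 2 gives 61.4%. Compound 2 stands lowest of the two, and the gap to compound 1 lies beyond the scatter. Compound 3 `N=C(N)N/N=C/c1cn(-c2ccccc2)nc1-c1ccc(Cl)cc1` differs from compound 2 by chloro in place of fluoro on an aromatic carbon. Among the compounds with values here, no measured pair shows this change, so its effect is unknown; a small step, in either direction and not clearly beyond the scatter, is expected. The step from compound 2 to compound 3 is estimated at a number 1.6 percentage points higher from compound 2 to compound 3 (within the scatter). Compound 3 is expected to give 63%, within a range from 45% to 80%.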

Compound 3, a percentage reported as inhibition, in the whole organism at one dose (the size of the read-out at that dose, not a potency): 46%
Estimate against measurement, compound 3: 17 percentage points above; low and high end bracket the measured number.
By their numbers in this assay, from the lowest: compound 3; then compound 2; then compound 1.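

In this assay, chloro in place of fluoro on an aromatic carbon, para to a large group, gives a number 15.4 percentage points lower from compound 2 to compound 3 (beyond the scatter), so the read-out responds to the exchange of one halogen for another at this position. Compound 1 and compound 2 differ in more than one place and could not show this. Nothing available explains the drop.

Open, from the compounds shown here alone, is how this position behaves with a group other than a halogen, such as a methoxy group or an amine. Also open, going by these compounds, is whether the same exchange has a similar effect on a different substitution pattern elsewhere on the core.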